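The compounds below may be only part of what the source reports. "The series", "measured", "known", "first", "only" and "open" are said of these compounds alone.

Measured so far in a functional assay on cells for agonist activity at Free fatty acid receptor 1 (Homo sapiens), read by FLIPR and calcium flux, with a stated time of 60 min; a lower number here means a smaller maximal response, a higher number a larger maximal response:

- compound 1, `COc1ccc(F)c(-c2ccc(COc3cccc([C@@H](CC(=O)O)C4CC4)c3)nc2CC(C)(C)C)c1`: 66%
- compound 2, `COc1ccc(CCCC(C)(C)C)c(-c2ccc(COc3cccc(C(CC(=O)O)C4CC4)c3)cc2)c1`: 105%
- compound 3, `COc1ccc(C)c(N2CCC(COc3cccc(C(CC(=O)O)C4CC4)c3)CC2)c1`: 113%

Compound 3 gives the largest of the three numbers, but compound 2 sits within the usual scatter of it, so the two are not separated; only compound 1 lies beyond the scatter, well under compound 3.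

Compound 4, `COc1ccc(CCC(C)(C)O)c(N2CCC(COc3cccc(C(CC(=O)O)C4CC4)c3)CC2)c1`, carries 2-hydroxy-2-methylpropyl in place of hydrogen on a saturated chain carbon bound to an aromatic carbon relative to compound 3, on a saturated chain carbon bound to an aromatic carbon. Among the compounds with values here, no measured pair shows this change, so the step from compound 3 to compound 4 in this assay is expected to be small, a number 8 percentage points lower from compound 3 to compound 4 (within the scatter), at most a modest loss not clearly beyond the scatter.

Compound 4 is therefore estimated at 105%, in the range 85% to 120%.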

Compound 4, largest response reached (Emax), in percent of the reference or control that the assay uses: 109%
The estimate for compound 4 lay 4 percentage points below the measured number; the range from low to high includes it.
By their numbers in this assay, from the lowest: compound 1; then compounds 2, 4 and 3 (each within the scatter of the next).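

In this assay, 2-hydroxy-2-methylpropyl in place of hydrogen on a saturated chain carbon bound to an aromatic carbon gives a number 4 percentage points lower from compound 3 to compound 4 (within the scatter). Within the data shown here, this is the first step between compounds that differ in one place, and it shows that this position accepts a branched hydroxyl-bearing chain without a loss beyond the scatter. Nothing available bears on the reason for this result.

Still open, going by these compounds, is whether an amine in place of the hydroxyl, or a longer chain, would stay within the scatter of compound 3. One step sets no trend for this position.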